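The source may report more compounds than this note shows. Statements on the series, on what has been measured and on what is new or still open speak of the compounds shown alone.

Measured compounds:

compound 1, `N=C(N)NCCC[C@H](NC(=O)CN(c1ncnc2c1ncn2C1CCCCO1)C1CC1)C(=O)OCc1ccccc1`, 34.3%
compound 2, `CSCC[C@H](NC(=O)CN(c1nc(Cl)nc2[nH]cnc12)C1CC1)C(=O)OCc1ccccc1`, 22.2%
compound 3, `C[C@H](NC(=O)CN(c1nc(Cl)nc2[nH]cnc12)C1CC1)C(=O)O`, 48.1%

These three compounds were tested in a functional assay on the whole organism (Tail, strain ICR) with Mus musculus as the target, in the tail flick test, with a stated time of 30 min, at a dose of 25 umol/kg by the oral route; on this read-out higher numbers stand for a stronger effect at the one dose given and lower numbers for a weaker effect. Compound 2 stands lowest of the three numbers. The nearest of the others is compound 1, whose value lies higher by a gap beyond the scatter, and the furthest is compound 3, whose value lies higher by a still larger gap, also beyond the scatter. Going by the values given here, neither compound 1 nor compound 3 differs from compound 2 in only one place, so no single step between measured compounds can be read from these values, and the list gives no step of the kind now in question.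

The next compound, compound 4, has the structure `CC[C@H](C)[C@H](NC(=O)CN(c1nc(Cl)nc2[nH]cnc12)C1CC1)C(=O)OCc1ccccc1`. It is derived from compound 2 by one change: sec-butyl in place of 2-(methylsulfanyl)ethyl on a saturated chain carbon bound to an amide-type nitrogen and a carbonyl carbon. The rest of the molecule, including the shared core, is unchanged.

Among the compounds with values here, with no measured step of this kind to lean on, the expectation is a small shift in this assay, upward if any, of about a number 7.8 percentage points higher from compound 2 to compound 4 (within the scatter), which may well lie within the usual scatter. Compound 4 is therefore estimated at 30%, with a range from 12% to 50%.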

Compound 4, a percentage reported as activity, at one dose (the size of the read-out at that dose, not a potency): 41.4%
Estimate against measurement, compound 4: 11.4 percentage points below, within the range that was stated.
By their numbers in this assay, from the lowest: compound 2; then compounds 1, 4 and 3 (each within the scatter of the next, the first and the last beyond it).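

In this assay, the position on a saturated chain carbon bound to an amide-type nitrogen and a carbonyl carbon now gives its first readable single change: sec-butyl in place of 2-(methylsulfanyl)ethyl gives a number 19.2 percentage points higher from compound 2 to compound 4 (beyond the scatter). The two groups hold the same number of heavy atoms, yet the change exchanges the sulfur of the chain for carbon and brings a defined stereocentre, so this position responds to a swap that leaves that count untouched. No measurement shown here explains the rise.

A single step cannot separate the loss of sulfur from the change in chain shape, and an unbranched butyl chain at this position would be needed to pull those two apart. Going by these compounds, it also remains open how this position would respond to a chain ending in an amine or to a longer chain, and whether the step would hold with the carboxylic acid in place of the benzyl ester.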